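From Propyl to Vinyl: Expected Tolerance of Compound 4

This account rests on a few compounds, and the source may have more. Where it says the series, first, only, none or still open, it means among the compounds named here.

Of the compounds shown here, three sharing one core have been tested in an ADME assay on MDCK cells (Canis lupus familiaris) for cytotoxicity, read by microscopy, with a stated time of 48 h; a lower number here means that less compound is tolerated, a higher number that more compound is tolerated. Compound 1 `CCc1csc(CN[C@@H]2C[C@H]3C[C@@H]([C@H]2C)C3(C)C)c1` gives 25000 nM, compound 2 `C=C(C)c1csc(CN[C@@H]2C[C@H]3C[C@@H]([C@H]2C)C3(C)C)c1` gives 25000 nM, and compound 3 `CCCc1csc(CN[C@@H]2C[C@H]3C[C@@H]([C@H]2C)C3(C)C)c1` gives 12500 nM. Compound 3 carries the lowest of the three numbers, yet its gap to each of the others lies within the scatter, so no real difference among them can be read. Compound 4 `C=Cc1csc(CN[C@@H]2C[C@H]3C[C@@H]([C@H]2C)C3(C)C)c1` differs from compound 3 by vinyl in place of propyl on an aromatic carbon. Within the data shown here, the steps that bear on this change are all small: no change at the digits printed from compound 1 to compound 2 (within the scatter), a 2.0-fold lower number from compound 1 to compound 3 (0.30 log units; within the scatter) and a 2.0-fold lower number from compound 2 to compound 3 (0.30 log units; within the scatter). Exchanging one small carbon group for another on this aromatic carbon has so far produced nothing beyond the scatter. For compound 4 the expected step is a 2.0-fold higher number from compound 3 to compound 4 (0.30 log units; within the scatter), which gives an estimate of 25000 nM, with a range from 12500 nM to 50000 nM.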

Compound 4, minimum cytotoxic concentration: 6250 nM
Estimate against measurement, compound 4: 4.0-fold (0.60 log units) above; the measured number lies below the stated range.
By their numbers in this assay, from the lowest: compounds 4, 3, 1 and 2 (each within the scatter of the next, the first and the last beyond it).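

Vinyl in place of ethyl gives a 4.0-fold lower number from compound 1 to compound 4 (0.60 log units; beyond the scatter) and hydrogen in place of methyl on the double-bonded chain carbon gives a 4.0-fold lower number from compound 2 to compound 4 (0.60 log units; beyond the scatter), the first steps at this position beyond the scatter. Vinyl in place of propyl, by contrast, gives a 2.0-fold lower number from compound 3 to compound 4 (0.30 log units; within the scatter), so compound 3 and compound 4 cannot be told apart. A double bond alone does not bring the number down, as 1-methylethenyl also has one and compound 2 gives 25000 nM.

Nothing measured here offers a reason for these steps. Also open, going by these compounds, is how an amine, a carboxylic acid or a chain longer than propyl at this carbon would behave.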